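This account rests on a few compounds, and the source may have more. Where it says the series, first, only, none or still open, it means among the compounds named here.

The measured compounds in an ADME assay on PC-3 cells (Homo sapiens) for cytotoxicity, read by WST assay, tested at 100 uM; on this read-out lower numbers stand for less inhibition and higher numbers for more inhibition at the one concentration tested (going by the name of the read-out):
compound 1 `CC(C)(C)OC(=O)c1cccc(NC(=O)C2CCCN(C(=O)c3cc(C(F)(F)F)cc(C(F)(F)F)c3)C2)c1` gives 0%;
compound 2 `O=C(Nc1cccc(Oc2ccccc2)c1)C1CCCN(C(=O)c2cc(C(F)(F)F)cc(C(F)(F)F)c2)C1` gives 1%.

In this assay, within the data shown here, compound 2 stands within the usual scatter of compound 1, the only other compound measured, so neither can be called more or less inhibiting than the other. Among the measured compounds shown here, the single measured step, a number 1 percentage points higher from compound 1 to compound 2 (within the scatter), exchanged one group on an aromatic carbon of the shared core and left the read-out essentially where it was. Compound 3 `CC(=O)c1cccc(NC(=O)C2CCCN(C(=O)c3cc(C(F)(F)F)cc(C(F)(F)F)c3)C2)c1` differs from compound 2 in one group on an aromatic carbon: acetyl in place of phenoxy on an aromatic carbon. Because the comparable exchange a number 1 percentage points higher from compound 1 to compound 2 (within the scatter) did not move the number beyond the scatter, no step beyond the scatter is expected for this exchange either. The step from compound 2 to compound 3 is therefore expected to be no change at the digits printed from compound 2 to compound 3 (within the scatter). For compound 3 in this assay the estimate is 1%, with a range from 0% to 12%.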

Compound 3, a percentage reported as inhibition, at one concentration (the size of the read-out at that concentration, not a potency): 0%
Estimate against measurement, compound 3: 1 percentage points above, within the range that was stated.
By their numbers in this assay, from the lowest: compounds 1, 3 and 2 (each within the scatter of the next).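

In this assay, putting acetyl in place of phenoxy removes a six-membered aromatic ring from this position and gives a number 1 percentage points lower from compound 2 to compound 3 (within the scatter), so that ring is not needed to hold the number where it stands. Exchanging tert-butoxy for methyl on the carbonyl carbon gives no change at the digits printed from compound 1 to compound 3 (within the scatter), so the size of the group on that carbonyl does not separate these two compounds either. Three different groups on this aromatic carbon, meta to a large group, now read alike, and all of them give numbers close to no inhibition at the one concentration tested.

As far as these compounds go, whether an amine or a carboxylic acid at this position would give a number beyond the scatter remains open. Nothing available explains why these three compounds read alike.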